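Quinolinylmethoxy series: carboxylic acid for tetrazole on the other core

A few compounds are considered here, and "the series" means these few. Any claim that something is new, unique, unknown or untested is made for them only; others in the source may bear on it.

Measured compounds:
compound 1 `CCCC(CCC(=O)O)Cc1ccc(OCc2ccc3ccccc3n2)cc1` gives 30 nM
compound 2 `CC(CCc1nnn[nH]1)Cc1ccc(OCc2ccc3ccccc3n2)cc1` gives 27 nM
compound 3 `CC(CCc1nnn[nH]1)Cc1cccc(OCc2ccc3ccccc3n2)c1` gives 150 nM

In a functional assay (lung) for inhibition, with Cavia porcellus as the target (a higher number here means a weaker inhibitor, a lower number a stronger inhibitor), compound 2 and compound 1 sit close together: the change 1-(2-carboxyethyl)butyl in place of 3-(1H-tetrazol-5-yl)-1-methylpropyl on a saturated chain carbon bound to an aromatic carbon gives a 1.1-fold higher number from compound 2 to compound 1 (0.05 log units; within the scatter). Compound 3 carries the same side chain as compound 2 on a core with the same atoms joined differently; the difference between the two cores is not broken down here. In this assay compound 3 gives 150 nM, the highest of the three numbers, and both compound 1 and compound 2 lie beyond the scatter from it.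

Compound 4 `CCCC(CCC(=O)O)Cc1cccc(OCc2ccc3ccccc3n2)c1` is not yet measured. It arises from compound 3 by 1-(2-carboxyethyl)butyl in place of 3-(1H-tetrazol-5-yl)-1-methylpropyl on a saturated chain carbon bound to an aromatic carbon, the same change as between compound 2 and compound 1, at the same place, on the core of compound 3. Among the compounds shown this change occurs twice in all, and the one measured instance of it was within the scatter. Among the measured compounds shown here, the expectation is that on the core of compound 3 it behaves alike, resting on the single observed step of a 1.1-fold higher number from compound 2 to compound 1 (0.05 log units; within the scatter); with only one precedent, and on a different core, the range must stay wide.

For compound 4 in this assay the estimate is 160 nM, between 70 nM and 360 nM, which is expected to mean a step of a 1.1-fold higher number from compound 3 to compound 4 (0.03 log units; within the scatter).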

Compound 4, half-maximal inhibitory concentration: 70 nM
Compound 4: middle estimate off by 2.3-fold (0.36 log units), on the high side; the range from low to high includes it.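

In this assay the 1-(2-carboxyethyl)butyl group in place of 3-(1H-tetrazol-5-yl)-1-methylpropyl gives a 2.1-fold lower number from compound 3 to compound 4 (0.33 log units; beyond the scatter) on the core of compound 3, a modest step that lies beyond the scatter. Read alone, this step differs in standing from the earlier one, which lies within the scatter, but the two steps cannot be told apart when set side by side: the same change on two cores in this assay, a 1.1-fold higher number (0.05 log units; within the scatter) from compound 2 to compound 1 and a 2.1-fold lower number (0.33 log units; beyond the scatter) from compound 3 to compound 4, 2.4-fold (0.38 log units) apart, within the scatter of two such steps. The series therefore shows no measurable dependence of this change on the core, and on both cores the open-chain carboxylic acid stands up to the tetrazole-bearing chain without loss, yet two pairs cannot show that the step is the same on every core, nor can they rule out a small difference between these two cores.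

Open, from the compounds shown here alone, is how the change behaves on any further core, and which part of it carries the step, since the acid and tetrazole groups arrive on chains that also differ in their branch. A sulfonamide or an amide at the chain end, or a propyl branch kept with the tetrazole, would separate these contributions.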